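The compounds below may be only part of what the source reports. "The series", "measured", "known", "first", "only" and "open" are said of these compounds alone.

Measured in an ADME assay on microsomes from liver (Mus musculus) for metabolic stability; a lower number here means slower removal, a higher number faster removal of the compound:
compound 1 `O=C(O)C1(c2nn(Cc3cn4cc(OCC5CC5)c(Cl)cc4n3)c3ccccc3c2=O)CC1`: < 53.4 mL/min/kg
compound 2 `CC(C)(C(=O)O)c1nn(Cc2cn3cc(OCC4CC4)c(Cl)cc3n2)c2ccccc2c1=O`: < 63.4 mL/min/kg

Both values are limits, not numbers. Compound 2 therefore stands only at a limit, < 63.4 mL/min/kg. Compound 3 `C[C@H](C(=O)O)c1nn(Cc2cn3cc(OCC4CC4)c(Cl)cc3n2)c2ccccc2c1=O` differs from it in one place: 1-carboxyethyl in place of 1-carboxy-1-methylethyl on an aromatic carbon. Among the measured compounds shown here, the only measured step bearing on this change is a step that the two limits leave unreadable from compound 1 to compound 2, and its size cannot be read from the two limits. It gives no size or direction for a step in this assay, so nothing beyond the scatter is expected. The estimated step is a step that the limit leaves unreadable from compound 2 to compound 3. Compound 3 is expected at 45 mL/min/kg, with an estimated range of 20 mL/min/kg to 75 mL/min/kg.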

Compound 3, clearance: < 53.4 mL/min/kg
Compound 3: a limit, no number; the forecaster's own chance of this, stated with the estimate: 65%; the middle value lies beyond the limit too.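

In this assay compound 3 gives < 53.4 mL/min/kg, which is a limit. Among the compounds shown here, compound 1 and compound 2 also stand only at limits, so no step among the three compounds can be read. On these data alone, how 1-carboxyethyl, 1-carboxy-1-methylethyl and 1-carboxycyclopropyl compare in clearance stays open.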